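Carbamate to urea in a butynylamine series

This account rests on a few compounds, and the source may have more. Where it says the series, first, only, none or still open, it means among the compounds named here.

Measured so far:
compound 1, `COC(=O)N(C)CC#CCN1CCCC1`: > 10 mg/kg
compound 2, `COC(=O)N(C)CC#CCN(C)C`: > 30 mg/kg

In a functional assay on the whole organism for antagonist activity, with Mus musculus as the target (on this read-out higher numbers stand for an effect only at larger amounts of compound and lower numbers for an effect already at smaller amounts), compound 1 gives only a limit of the measurement, > 10 mg/kg. Compound 2 likewise gives only a limit in this assay, > 30 mg/kg. Within the data shown here, the one measured step, a step that the two limits leave unreadable from compound 1 to compound 2, is not readable in size, since the limit of > 10 mg/kg in this assay, at which 1 of the 2 values shown sits, and the limit of > 30 mg/kg in this assay, at which 1 of the 2 values shown sits, are both limits rather than numbers; it changes the amine end of the chain and leaves the carbonyl end untouched.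

Compound 3, `CN(C)C(=O)N(C)CC#CCN1CCCC1`, is not yet measured in this assay. It differs from compound 1 by dimethylamino in place of methoxy on a carbonyl carbon. Among the measured compounds shown here, no measured step bears on this change: the measured pair varies the amine, not the carbonyl substituent, so the series gives no size to expect from it. Compound 1 itself stands only at a limit in this assay, with no number to move from.

The step that the limit leaves unreadable from compound 1 to compound 3 is therefore expected to be small, within the scatter, in either direction. Compound 3 is estimated at 15 mg/kg in this assay, in a range from 5 mg/kg to 45 mg/kg, and a limit rather than a number is expected as the more likely report.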

Compound 3, dose for half-maximal effect: 6.6 mg/kg
Estimate against measurement, compound 3: 2.3-fold (0.36 log units) above; the range from low to high includes it.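

In this assay compound 3, with dimethylamino in place of methoxy on a carbonyl carbon, gives a measured number, 6.6 mg/kg. Compound 1 and compound 2 each gave only a limit of the measurement. Among these compounds, the change therefore reads as an at least 1.5-fold lower number from compound 1 to compound 3 (0.18 log units; that floor lies within the scatter), the first readable step and the first sign that the carbonyl substituent can be followed with numbers, although the floor alone does not establish a real difference. The true size stays unfixed because compound 1 stands at a limit and not at a number: the limit of > 10 mg/kg in this assay, at which 1 of the 3 values shown sits.

From the compounds shown here alone, the step between the two amine ends cannot be read, so what pyrrolidin-1-yl and dimethylamino each contribute at that end remains open, on the carbamate and on the urea alike. Also open, going by these compounds, is how far the carbonyl position tolerates change, for instance with ethoxy, methylamino or pyrrolidin-1-yl on the carbonyl carbon, and whether piperidin-1-yl at the amine end would keep a measurable number in this assay.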